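The source may hold more compounds than are shown below. What is called first, only, known or untested is meant among the compounds shown, and "the series" means these compounds.

Measured compounds:
compound 1 `CN1CCN(CCCCCCn2c3c(c4ccccc42)C(=O)c2c[n+]([O-])c4ccccc4c2C3=O)CC1`, in a toxicity assay on L02 cells (Homo sapiens) for cytotoxicity, read by MTT assay, with a stated time of 72 h (a lower number here means a stronger inhibitor, a higher number a weaker inhibitor), compound 1 gives 3800 nM
compound 2 `O=C1c2c[n+]([O-])c3ccccc3c2C(=O)c2c1c1ccccc1n2Cc1cn(CC(O)CO)nn1`, in this assay compound 2 gives 1070 nM
compound 3 `CN1CCN(CCCn2c3c(c4ccccc42)C(=O)c2c[n+]([O-])c4ccccc4c2C3=O)CC1`, in this assay compound 3 gives 230 nM

Compound 3 has the lowest number of the three in this assay. Its nearest neighbour is compound 2, with a 4.7-fold lower number from compound 2 to compound 3 (0.67 log units; beyond the scatter), and its furthest is compound 1, with a 17-fold lower number from compound 1 to compound 3 (1.22 log units; beyond the scatter), both beyond the scatter.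

Compound 4 `CCCN1CCN(CCCCn2c3c(c4ccccc42)C(=O)c2c[n+]([O-])c4ccccc4c2C3=O)CC1` has not yet been measured. Relative to compound 3 the change is (4-propylpiperazin-1-yl)methyl in place of 4-methylpiperazin-1-yl on a saturated chain carbon, three bonds along the chain from an aromatic nitrogen. The measured step that bears most directly on it is a 17-fold lower number from compound 1 to compound 3 (1.22 log units; beyond the scatter), where the compound with the longer chain to the piperazine carried the higher number. Going by the values given here, compound 4 again lengthens that chain, though by less than the gap from compound 3 to compound 1, and it also replaces methyl by propyl on the far piperazine nitrogen, for which no measured pair exists. The steps of a 3.6-fold lower number from compound 1 to compound 2 (0.55 log units; beyond the scatter) and a 4.7-fold lower number from compound 2 to compound 3 (0.67 log units; beyond the scatter) concern a different group and bear only indirectly.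

A modest rise in this assay is therefore expected, with the expected step being a 2.4-fold higher number from compound 3 to compound 4 (0.38 log units; beyond the scatter). For compound 4 the estimate is 550 nM, with a range of 200 nM to 1600 nM.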

Compound 4, half-maximal inhibitory concentration: 6830 nM
Compound 4: the middle estimate sits 12-fold (1.09 log units) below what was measured; measured number outside the range, above it.
By their numbers in this assay, from the lowest: compound 3; then compound 2; then compounds 1 and 4 (each within the scatter of the next).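

In this assay, the step of a 30-fold higher number from compound 3 to compound 4 (1.47 log units; beyond the scatter) shows that this place tolerates the change poorly: going from 2-(4-methylpiperazin-1-yl)ethyl to 3-(4-propylpiperazin-1-yl)propyl costs more than the earlier chain step a 17-fold lower number from compound 1 to compound 3 (1.22 log units; beyond the scatter) suggested, although compound 4 carries the shorter chain of the two compared with compound 1. The step of a 1.8-fold higher number from compound 1 to compound 4 (0.25 log units; within the scatter) lies within the scatter, so among the piperazine compounds the number does not simply follow chain length, and compound 4 goes against any such reading, while a 6.4-fold higher number from compound 2 to compound 4 (0.81 log units; beyond the scatter) places the 3-(4-propylpiperazin-1-yl)propyl compound well on the high side of the compound with the 1-(2,3-dihydroxypropyl)-1H-1,2,3-triazol-4-yl group. No supporting evidence is available to explain these steps.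

The longer chain and the propyl group change together here, and no pair among the compounds shown separates their shares of the rise. Going by these compounds, how a 4-ethylpiperazin-1-yl or a morpholin-4-yl group would read on the chain of compound 3 or of compound 4 remains open.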